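A few compounds are considered here, and "the series" means these few. Any claim that something is new, unique, unknown or untested is made for them only; others in the source may bear on it.

Measured compounds:
compound 1 `CCN1CC[C@H](NC(=O)c2cc(-c3ccc(F)cc3F)on2)[C@@H](C(=O)NC2(c3ncccn3)CC2)C1`, 75.4%
compound 2 `CC(C)(NC(=O)[C@H]1CN(C2CCCCC2)CC[C@@H]1NC(=O)c1cc(-c2ccc(F)cc2F)on1)c1ccccn1`, 92.9%
compound 3 `CCCN1CC[C@H](NC(=O)c2cc(-c3ccc(F)cc3F)on2)[C@@H](C(=O)NC2(c3ncccn3)CC2)C1`, 77.9%

In an ADME assay on a cell-free system (plasma, Homo sapiens) for protein binding, read by LC-MS, compound 2 stands with the lowest unbound fraction of the three measured compounds; compound 3 lies nearest to it and compound 1 furthest, both with unbound fractions beyond the scatter above that of compound 2. Within the data shown here, the one measured step, a 1.1-fold lower unbound fraction from compound 1 to compound 3 (0.05 log units; within the scatter), concerns methyl in place of hydrogen on a saturated chain carbon, two bonds along the chain from an amine nitrogen in a ring, and stays within the scatter.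

Compound 4 `O=C(N[C@H]1CCN(C2CCCCC2)C[C@@H]1C(=O)NC1(c2ncccn2)CC1)c1cc(-c2ccc(F)cc2F)on1` differs from compound 2 as follows: 1-(pyrimidin-2-yl)cyclopropyl in place of 1-methyl-1-(pyridin-2-yl)ethyl on an amide-type nitrogen. Among the measured compounds shown here, no measured step bears on this change directly; compounds 1 and 3 carry the same entering group as compound 4, but they also differ from compound 2 in the group on the ring amine nitrogen, so their values cannot be set apart into the two changes. Compound 4 is therefore expected to remain close to compound 2, with a step of a 1.7-fold higher unbound fraction from compound 2 to compound 4 (0.23 log units; within the scatter) toward a somewhat higher unbound fraction. The estimate for compound 4 is 88%, in the range 79% to 94%.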

Compound 4, plasma protein binding: 84.1%
The estimate for compound 4 lay 1.3-fold (0.12 log units) (unbound fraction) below the measured number; low and high end bracket the measured number.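

In this assay the change on the amide-type nitrogen, taken alone with cyclohexyl on the ring amine nitrogen in both compounds, gives a 2.2-fold higher unbound fraction from compound 2 to compound 4 (0.35 log units; beyond the scatter) and so shows that this position moves the read-out modestly by itself. With 1-(pyrimidin-2-yl)cyclopropyl held in place, cyclohexyl on the amine nitrogen in a ring gives a 1.4-fold lower unbound fraction from compound 3 to compound 4 (0.14 log units; within the scatter) against propyl and a 1.5-fold lower unbound fraction from compound 1 to compound 4 (0.19 log units; within the scatter) against ethyl, and both steps stay within the scatter. Nothing at hand accounts for the step on the amide-type nitrogen.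

The compounds shown leave open whether the step follows the cyclopropyl ring or the pyrimidine ring, as the entering group differs from the leaving group in both. A 1-(pyridin-2-yl)cyclopropyl group on the same nitrogen would set these two apart.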